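From hydrogen to trifluoromethyl on compound 3

The source may hold more compounds than are shown below. What is called first, only, known or untested is meant among the compounds shown, and "the series" means these compounds.

In a functional assay on KG-1 cells (Homo sapiens) for cytotoxicity, read by luminescence and CellTiter-Glo, with a stated time of 3 days (on this read-out lower numbers stand for stronger inhibition and higher numbers for weaker inhibition), compound 3 `O=C(Nc1ccccc1)c1cc(F)ccc1O` gives > 10000 nM, which is a limit of the assay and not a number. Compound 4 `O=C(Nc1cccc(C(F)(F)F)c1)c1cc(F)ccc1O` differs from it in one place: trifluoromethyl in place of hydrogen on an aromatic carbon.

Going by the values given here, no measured step involves trifluoromethyl itself, so the closest guides are two compounds that carry cyano where compound 3 has hydrogen. Compound 1 `N#Cc1cccc(NC(=O)c2cc(F)ccc2O)c1` gives 9100 nM, and compound 2 `N#Cc1ccc(NC(=O)c2cc(F)ccc2O)cc1` gives 2670 nM. Putting hydrogen in place of cyano gives an at least 1.0-fold higher number from compound 1 to compound 3 (0.04 log units; that floor lies within the scatter). The same exchange also gives an at least 3.7-fold higher number from compound 2 to compound 3 (0.57 log units; beyond the scatter). Both sizes are only floors, since compound 3 has no exact number.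

In compound 1 the cyano also stands meta to a large group, as trifluoromethyl does in compound 4, so this pair is the better match, although its floor of an at least 1.0-fold higher number from compound 1 to compound 3 (0.04 log units; that floor lies within the scatter) says little. The clearer step, an at least 3.7-fold higher number from compound 2 to compound 3 (0.57 log units; beyond the scatter), suggests that a group in place of that hydrogen can lower the number. A modest move towards stronger inhibition is therefore expected, estimated as an at least 2.5-fold lower number from compound 3 to compound 4 (0.39 log units; beyond the scatter). Trifluoromethyl is not cyano, so this estimate is loose, and compound 4 may also stay at the limit. For compound 4 the expected value is 4000 nM, with an estimated range of 1200 nM to 12000 nM.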

Compound 4, half-maximal inhibitory concentration: 1010 nM
Compound 4: the middle estimate sits 4.0-fold (0.60 log units) above what was measured, outside the stated range (below it).
By their numbers in this assay, from the lowest: compound 4; then compound 2; then compound 1. At a limit, above all of these: compound 3.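

In this assay, trifluoromethyl in place of hydrogen, meta to a large group, gives an at least 9.9-fold lower number from compound 3 to compound 4 (0.99 log units; beyond the scatter), so this place on the ring clearly responds to a change, which the cyano compound with the same arrangement could not show, as its floor lay within the scatter. The choice of group also counts: trifluoromethyl in place of cyano gives a 9.0-fold lower number from compound 1 to compound 4 (0.95 log units; beyond the scatter), so what matters here is which group stands at this place, not merely that a group is there. The step from compound 3 is only a floor, since compound 3 carries a limit of the assay and not a number: the limit of > 10000 nM in this assay, at which 1 of the 4 values shown sits.

Going by these compounds, how a methyl group, a chlorine atom or an amine at this place would compare with trifluoromethyl remains open, and so does whether trifluoromethyl would lower the number further at the place that cyano holds in compound 2. These values also cannot say which feature of trifluoromethyl lies behind the step, so the result describes a change in the number and gives no explanation for it.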